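Phenyl for ethyl on the amide-type nitrogen

The compounds below may be only part of what the source reports. "The series", "measured", "known", "first", "only" and "open" are said of these compounds alone.

Measured so far in a physicochemical assay for solubility, at pH 7; on this read-out lower numbers stand for lower solubility and higher numbers for higher solubility:
Compound 1 `CN1CCN(c2ccc(C(=O)Nc3n[nH]c4cc(C(=O)NC(C)(C)c5ccccc5)sc34)cc2)CC1` gives 2000 nM
Compound 2 `CCNC(=O)c1cc2[nH]nc(NC(=O)c3ccc(N4CCN(C)CC4)cc3)c2s1` gives 67000 nM

Compound 2 holds the higher of the two numbers, with 67000 nM on this read-out. Compound 3 `CN1CCN(c2ccc(C(=O)Nc3n[nH]c4cc(C(=O)Nc5ccccc5)sc34)cc2)CC1` is still unmeasured and differs from it by this change (phenyl in place of ethyl on an amide-type nitrogen), phenyl in place of ethyl on an amide-type nitrogen. Among the measured compounds shown here, the one measured step on that nitrogen was large (a 34-fold higher number from compound 1 to compound 2 (1.53 log units; beyond the scatter)), so a large move to a lower number is expected in this assay for compound 3, perhaps somewhat smaller than that step. The estimated step is (an 11-fold lower number from compound 2 to compound 3 (1.05 log units; beyond the scatter)). For compound 3 the estimated value is 6000 nM (expected range 1500 nM to 24000 nM).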

Compound 3, solubility: 6000 nM
Beside the measured number, compound 3's estimate shows no gap at the digits printed; low and high end bracket the measured number.
By their numbers in this assay, from the lowest: compound 1; then compound 3; then compound 2.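

In this assay, replacing the ethyl of compound 2 with phenyl gives an 11-fold lower number from compound 2 to compound 3 (1.05 log units; beyond the scatter) on this read-out, so the ethyl compound stays clearly on top of a second comparison at the amide-type nitrogen. Phenyl in place of 1-methyl-1-phenylethyl gives a 3.0-fold higher number from compound 1 to compound 3 (0.48 log units; beyond the scatter) and shows that the two groups carrying a ring also differ from each other, though by a modest step. Nothing available gives a reason for either step.

The three compounds do not show whether the ring itself or the number of heavy atoms sets the order. On these data alone, how a longer chain such as n-butyl, or an amine such as 2-aminoethyl, on this nitrogen would compare remains open.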